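A few compounds are considered here, and "the series" means these few. Any claim that something is new, unique, unknown or untested is made for them only; others in the source may bear on it.

Measured in a functional assay on L02 cells (Homo sapiens) for inhibition, read by Griess assay, with stated times of 1 h and 24 h; on this read-out higher numbers stand for weaker inhibition and lower numbers for stronger inhibition:
- compound 1 `CNc1nc(/C=C/c2ccccc2)nc2ccsc12` gives > 1000000 nM as a limit
- compound 2 `C(=C/c1nc(Nc2ccccc2)c2sccc2n1)\c1ccccc1` gives > 1000000 nM as a limit
- compound 3 `Fc1ccc(CNc2nc(/C=C/c3ccccc3)nc3ccsc23)cc1` gives > 1000000 nM as a limit

Compound 3 has no number, only a limit, and the other two compounds share it: the limit of > 1000000 nM in this assay, at which 3 of the 3 values shown sit, is the whole picture so far.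

The next compound is compound 4 `Brc1ccc(CNc2nc(/C=C/c3ccccc3)nc3ccsc23)cc1`, with bromo in place of fluoro on an aromatic carbon, para to a large group (bromo in place of fluoro on an aromatic carbon). Going by the values given here, three measured steps bear on it: a step that the two limits leave unreadable from compound 1 to compound 3, a step that the two limits leave unreadable from compound 2 to compound 3 and a step that the two limits leave unreadable from compound 1 to compound 2. None of them has a readable size, and none changes the halogen itself.

With no reading yet under the limit, no step beyond the scatter is expected in this assay, and no direction can be given. The expected size is a number no higher from compound 3 to compound 4 (the limit leaves the size open) in this estimate. A further limit is the most likely report. For compound 4 the expected value is 1000000 nM, with an estimated range of 300000 nM to 3000000 nM.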

Compound 4, half-maximal inhibitory concentration: > 1000000 nM
Compound 4: a limit, no number (the forecaster's own chance of this, stated with the estimate: 85%); the middle value lies on the limit itself.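

Compound 4 gives only a limit in this assay, so none of the steps from compound 1, compound 2 or compound 3 to compound 4 can be read: the limit of > 1000000 nM in this assay, at which 4 of the 4 values shown sit.

The compounds shown leave open whether any change to the shared core gives a measurable inhibition value, and what size or direction any step would have.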